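This account rests on a few compounds, and the source may have more. Where it says the series, first, only, none or still open, it means among the compounds named here.

Measured so far in a functional assay on HCT-116 cells (Homo sapiens) for antiproliferative activity, read by CCK-8 assay, with a stated time of 72 h, tested at 8 uM; on this read-out higher numbers stand for a stronger effect at the one concentration tested and lower numbers for a weaker effect:
Compound 1 `Nc1ccccc1NC(=O)c1ccc(Cn2cnc3c(Nc4ccccc4)nc(Cl)nc32)cc1` gives 83.5%.
Compound 2 `Nc1ccccc1NC(=O)c1ccc(Cn2cnc3c(NCc4ccccc4)nc(Cl)nc32)cc1` gives 78.4%.

Going by the values given here, compound 2 stands lowest of the two numbers in this assay; its nearest neighbour is compound 1, and the only measured step, a number 5.1 percentage points lower from compound 1 to compound 2 (within the scatter), lies within the scatter. Compound 3 `Nc1ccccc1NC(=O)c1ccc(Cn2cnc3c(Nc4ccc(-c5ccccn5)cc4)nc(Cl)nc32)cc1` differs from compound 2 in one place: 4-(pyridin-2-yl)phenyl in place of benzyl on a nitrogen on an aromatic ring. Among the compounds with values here, the one step that bears on this nitrogen substituent is that from compound 1 to compound 2, where phenyl gave way to benzyl without a change beyond the scatter. Within the data shown here, no measured step involves 4-(pyridin-2-yl)phenyl, so the larger group brings no data of its own. Since compound 3 again carries an aromatic ring directly on that nitrogen, as compound 1 does, its value is expected to sit close to compound 1 and compound 2, with a number 3.6 percentage points higher from compound 2 to compound 3 (within the scatter) not expected to exceed the scatter. Compound 3 is therefore estimated at 82%, within 66% to 94%.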

Compound 3, a percentage reported as inhibition, at one concentration (the size of the read-out at that concentration, not a potency): 73.7%
Estimate against measurement, compound 3: 8.3 percentage points above, and the stated range covers the measured number.
By their numbers in this assay, from the lowest: compounds 3, 2 and 1 (each within the scatter of the next).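

In this assay the nitrogen on the aromatic ring also accepts the much larger 4-(pyridin-2-yl)phenyl, with a step of a number 4.7 percentage points lower from compound 2 to compound 3 (within the scatter) that stays within the scatter. Placing pyridin-2-yl in place of hydrogen on an aromatic carbon of the phenyl group gives a number 9.8 percentage points lower from compound 1 to compound 3 (within the scatter) and likewise stays within the scatter, so the three groups tried on this nitrogen cannot be told apart at the one concentration tested. No supporting measurement is available that bears on this result.

The compounds shown leave open whether a group without an aromatic ring on this nitrogen, such as a short alkyl chain or morpholine, would hold the effect. They also leave open whether a carboxylic acid or an amine in place of pyridin-2-yl would do so.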